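Amide aryl variation: from compound 3 to compound 4

The compounds below may be only part of what the source reports. "The series", "measured", "known", "first", "only" and "open" are said of these compounds alone.

Measured so far in a functional assay on A549 cells (Homo sapiens) for inhibition, read by MTT assay, with a stated time of 48 h; a higher number here means a weaker inhibitor, a lower number a stronger inhibitor:
compound 1 `COc1ccc2c(=O)c(/C=C/C(=O)Nc3cccc(Cl)c3)coc2c1` gives 470 nM
compound 2 `COc1ccc2c(=O)c(/C=C/C(=O)Nc3ccc(C)cc3)coc2c1` gives 17500 nM
compound 3 `CCOc1ccc(NC(=O)/C=C/c2coc3cc(OC)ccc3c2=O)cc1` gives > 100000 nM, which is a limit of the assay and not a number

Compound 3 stands at the weak end of the three measured values, and its reading sits at the limit (the limit of > 100000 nM in this assay, at which 1 of the 3 values shown sits), so only a bound is known for it. Compound 4 `COc1cccc(NC(=O)/C=C/c2coc3cc(OC)ccc3c2=O)c1`, still to be measured in this assay, differs from compound 3 in one place: 3-methoxyphenyl in place of 4-ethoxyphenyl on an amide-type nitrogen.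

Going by the values given here, two measured steps bear on this change. The amide aryl group was altered in an at least 210-fold higher number from compound 1 to compound 3 (2.32 log units; beyond the scatter) and in a 37-fold higher number from compound 1 to compound 2 (1.57 log units; beyond the scatter), both large, and the single substituent on that ring was altered in an at least 5.7-fold higher number from compound 2 to compound 3 (0.75 log units; beyond the scatter). Compound 1, whose aryl group carries its substituent as 3-chlorophenyl, is the strongest inhibitor among the three, and compound 4 carries its substituent on 3-methoxyphenyl rather than 4-ethoxyphenyl. A move toward the stronger side of the series is therefore expected, though the extent cannot be read from a limit. For compound 4 the expected step is an at least 6.6-fold lower number from compound 3 to compound 4 (0.82 log units; beyond the scatter), and the estimated value is 15000 nM, between 2000 nM and 100000 nM.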

Compound 4, half-maximal inhibitory concentration: 12800 nM
Compound 4: middle estimate off by 1.2-fold (0.07 log units), on the high side, and the stated range covers the measured number.
By their numbers in this assay, from the lowest: compound 1; then compounds 4 and 2 (each within the scatter of the next). At a limit, above all of these: compound 3.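

In this assay, 3-methoxyphenyl in place of 4-ethoxyphenyl gives an at least 7.8-fold lower number from compound 3 to compound 4 (0.89 log units; beyond the scatter), but the size of this step is only a bound, as compound 3 reads at a limit and not a number: the limit of > 100000 nM in this assay, at which 1 of the 4 values shown sits. Comparing 3-chlorophenyl with 3-methoxyphenyl isolates the group for the first time, since the earlier steps changed the group's name and its ring numbering together: methoxy in place of chloro gives a 27-fold higher number from compound 1 to compound 4 (1.44 log units; beyond the scatter), so the 3-numbering alone does not carry the strength of compound 1. 3-Methoxyphenyl in place of 4-methylphenyl gives a 1.4-fold lower number from compound 2 to compound 4 (0.14 log units; within the scatter), which leaves compound 4 and compound 2 indistinguishable in this series.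

Still open, as far as these compounds go, is whether chloro owes its standing to the group or to the combination of group and ring numbering, a question that 4-chlorophenyl and 4-methoxyphenyl amides would address. Also open, from the compounds shown here alone, is how other groups on that ring would read, such as fluoro, trifluoromethyl, an amine, a carboxylic acid or the longer 3-ethoxy chain.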